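Swapping the benzyl substituent on a xanthine-pyrazole series

A few compounds are considered here, and "the series" means these few. Any claim that something is new, unique, unknown or untested is made for them only; others in the source may bear on it.

Measured so far:
Compound 1 `CC(C)Cn1c(=O)c2nc(-c3cnn(Cc4cccc(F)c4)c3)[nH]c2n(CC(C)C)c1=O`: 990 nM
Compound 2 `CCCn1c(=O)c2nc(-c3ccnn3-c3ccccc3)[nH]c2n(CCC)c1=O`: 1100 nM
Compound 3 `CCCn1c(=O)c2nc(-c3cnn(Cc4cccc(C)c4)c3)[nH]c2n(CCC)c1=O`: 36 nM

In an in vitro assay on HEK293 cells for displacement of a labelled ligand from adenosine receptor A2b (Homo sapiens) (on this read-out lower numbers stand for stronger inhibition and higher numbers for weaker inhibition), compound 3 gives the lowest number of the three, and both compound 1 and compound 2 lie beyond the scatter above it, so compound 3 is the strongest binder here. Compound 4 `CCCn1c(=O)c2nc(-c3cnn(Cc4c(F)cccc4F)c3)[nH]c2n(CCC)c1=O` differs from compound 3 in one place: 2,6-difluorophenyl in place of 3-methylphenyl on a saturated chain carbon bound to an aromatic nitrogen. For the measured compounds named here, no measured pair isolates this change; compound 1 and compound 3 differ in this region but also in their chains. The step of a 4.2-fold higher number from compound 3 to compound 4 (0.62 log units; beyond the scatter) is expected to weaken binding by a modest, uncertain amount. Compound 4 is therefore estimated at 150 nM, with a range from 40 nM to 600 nM.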

Compound 4, inhibition constant: 390 nM
Compound 4: middle estimate off by 2.6-fold (0.41 log units), on the low side, within the range that was stated.
By their numbers in this assay, from the lowest: compound 3; then compound 4; then compounds 1 and 2 (each within the scatter of the next).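

In this assay, exchanging 3-methylbenzyl for 2,6-difluorobenzyl gives an 11-fold higher number from compound 3 to compound 4 (1.03 log units; beyond the scatter) and weakens binding well beyond the scatter. For the compounds shown here, this is the first pair differing in this one place alone, so the loss belongs to this change and not to the chains elsewhere on the core. Nothing measured here gives a reason for the loss.

The change removes a methyl group and adds two fluorines at once, so the pair cannot separate their contributions. Going by these compounds, how a plain benzyl group would compare on the same core remains open.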